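Trimming a Side Chain: From Compound 1 to Compound 3

The compounds below may be only part of what the source reports. "The series", "measured", "known", "first", "only" and "open" are said of these compounds alone.

Measured so far:
- compound 1, `CN1CCN(c2nc3ccccc3n2CCOCCO)CC1`: 42 nM
- compound 2, `CCCOCCn1c(N2CCCN(C)CC2)nc2ccccc21`: 16 nM

Both compounds were tested in a functional assay on ileum for inhibition of histamine H1 receptor (Cavia porcellus); a higher number here means a weaker inhibitor, a lower number a stronger inhibitor. In this assay compound 1 gives 42 nM, while compound 2 gives 16 nM. Of the two numbers, compound 1 therefore stands at the higher, weaker end, and the gap to compound 2 is beyond the usual scatter. Compound 2 differs from compound 1 in more than one place, so no single structural change can be read from that pair.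

Compound 3, `CCCn1c(N2CCN(C)CC2)nc2ccccc21`, has not been measured yet. It differs from compound 1 in one place: methyl in place of 2-hydroxyethoxy on a saturated chain carbon, two bonds along the chain from an aromatic nitrogen. The long chain that carries the hydroxyl is cut back to a short propyl, and the rest of the structure, including the shared core, stays the same.

Nothing measured here isolates that change. The expectation is a small step from compound 1 to compound 3, probably not beyond the scatter, perhaps toward a slightly lower number: a 1.4-fold lower number from compound 1 to compound 3 (0.15 log units; within the scatter). Compound 3 is estimated at 30 nM, with a range from 10 nM to 100 nM.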

Compound 3, half-maximal inhibitory concentration: 380 nM
For compound 3 the middle estimate is 13-fold (1.10 log units) below the measured one, outside the stated range (above it).
By their numbers in this assay, from the lowest: compound 2; then compound 1; then compound 3.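

In this assay, cutting the 2-(2-hydroxyethoxy)ethyl chain back to propyl gives a 9.0-fold higher number from compound 1 to compound 3 (0.96 log units; beyond the scatter), a step beyond the usual scatter and toward weaker inhibition. Among the compounds shown here, this is the first pair here that differs in only one place, and it shows that this chain position is not indifferent to what it carries: with methyl in place of 2-hydroxyethoxy, on a saturated chain carbon two bonds along the chain from an aromatic nitrogen, a clear part of the inhibition is lost. No measurement shown here explains the loss, so the step records what happens and not why it happens.

The change removes chain length, the ether oxygen and the terminal hydroxyl all at once, so this single step cannot show which of them matters. On the core of compound 1, a plain hexyl chain or a 2-(2-methoxyethoxy)ethyl chain would begin to separate these features, the first keeping the length without any oxygen and the second keeping the ether oxygen without the hydroxyl.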